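Extending the chloroacetamide arm of a sulfonate ester by one carbon

The source may report more compounds than this note shows. Statements on the series, on what has been measured and on what is new or still open speak of the compounds shown alone.

Compound 2 `CC(C)c1ccccc1OS(=O)(=O)c1cccc(NC(=O)CCl)c1` gives the lower of the two numbers seen so far in a functional assay on HT-29 cells (Homo sapiens) for antiproliferative activity, read by sulforhodamine B assay, with a stated time of 48 h; a lower number here means a stronger inhibitor, a higher number a weaker inhibitor; its neighbour compound 1 `CC(C)C(=O)Nc1cccc(S(=O)(=O)Oc2ccccc2C(C)C)c1` gives 16000 nM, while compound 2 gives 4500 nM. Among the compounds with values here, the one measured step, a 3.6-fold lower number from compound 1 to compound 2 (0.55 log units; beyond the scatter), came from the change to the chloromethyl group on the carbonyl carbon. Compound 3 `CC(C)c1ccccc1OS(=O)(=O)c1cccc(NC(=O)CCCl)c1` keeps that chain but lengthens it: chloromethyl in place of chloro on a saturated chain carbon bound to a carbonyl carbon. Within the data shown here, no measured step covers this exact change, so the only guidance is that compound 1, which lacks the chloromethyl group, gives 16000 nM, whereas compound 2 with it gives 4500 nM. Moving the chlorine one carbon further from the carbonyl is expected to cost part of that gain, so compound 3 is expected to show a 2.7-fold higher number from compound 2 to compound 3 (0.43 log units; beyond the scatter). Compound 3 is estimated at 12000 nM, within a range from 4000 nM to 40000 nM.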

Compound 3, half-maximal inhibitory concentration: 11000 nM
Beside the measured number, compound 3's estimate is 1.1-fold (0.04 log units) above it; the measured number falls inside the stated range.
By their numbers in this assay, from the lowest: compound 2; then compounds 3 and 1 (each within the scatter of the next).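

In this assay, the step of a 2.4-fold higher number from compound 2 to compound 3 (0.39 log units; beyond the scatter) shows that adding one carbon to this chain matters: the chlorine's presence alone does not set the number, and its distance from the carbonyl carbon counts too. The step of a 1.5-fold lower number from compound 1 to compound 3 (0.16 log units; within the scatter) lies within the scatter, so the 2-chloroethyl amide cannot be told apart from the isopropyl amide, and the gain seen with chloromethyl does not carry over to the longer chain. Nothing available here explains this difference between chloromethyl and 2-chloroethyl.

Still open, going by these compounds, is how a longer chain, such as 3-chloropropyl, would read at this carbonyl carbon. Also open, on these data alone, is whether another halogen, as in bromomethyl, would match or improve on the chloromethyl group of compound 2.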